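Compound 3 and the Ceiling of the Assay

The source may hold more compounds than are shown below. What is called first, only, known or untested is meant among the compounds shown, and "the series" means these compounds.

Measured in a functional assay on RAW264.7 cells (Mus musculus) for inhibition, with stated times of 2 h and 24 h (a lower number here means a stronger inhibitor, a higher number a weaker inhibitor), so far:
- Compound 1 `COc1ccc([C@@H]2c3c(OC)cc(OC)cc3C(SCc3ccc(C)cc3)[C@H]2c2cc(OC)cc(OC)c2)cc1` gives > 200000 nM (a limit)
- Compound 2 `COc1ccc([C@@H]2c3c(OC)cc(OC)cc3C(C(O)c3ccc(F)cc3)[C@H]2c2cc(OC)cc(OC)c2)cc1` gives > 200000 nM (a limit)
- Compound 3 `COc1ccc([C@@H]2c3c(OC)cc(OC)cc3C(C(O)c3ccc(Cl)cc3)[C@H]2c2cc(OC)cc(OC)c2)cc1` has not yet been measured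

Compound 2 has no exact number, only the limit of the assay, > 200000 nM as its reading. The same is true across the whole small set, which shows the limit of > 200000 nM in this assay, at which 2 of the 2 values shown sit, and no exact value. Compound 3 differs from compound 2 by a single swap on the outer ring: chloro in place of fluoro on an aromatic carbon. Among the measured compounds shown here, the one measured step, a step that the two limits leave unreadable from compound 1 to compound 2, has no size that could be carried over to this swap. With no measured size to go on, the expectation in this assay is no change beyond the scatter, and another reading at the limit is the likeliest result. The expected step is a number no higher from compound 2 to compound 3 (the limit leaves the size open) and it is only an estimate. The estimated value for compound 3 is 200000 nM with an expected range from 70000 nM to 300000 nM in this test.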

Compound 3, half-maximal inhibitory concentration: > 200000 nM
Compound 3 gave a limit, no number; the forecaster's own chance of this, stated with the estimate: 75%; the middle value lies on the limit itself.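

Compound 3 reads > 200000 nM, a limit and not a number. The steps to compound 3 from compound 1 and from compound 2 cannot be read, as every reading sits at one ceiling: the limit of > 200000 nM in this assay, at which 3 of the 3 values shown sit.

The compounds shown leave open how strongly any of them inhibits, and whether chloro in place of fluoro changes anything.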